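A few compounds are considered here, and "the series" means these few. Any claim that something is new, unique, unknown or untested is made for them only; others in the source may bear on it.

In a functional assay on HEK293 cells for inhibition of Voltage-dependent T-type calcium channel subunit alpha-1G (Homo sapiens) (a higher number here means a weaker inhibitor, a lower number a stronger inhibitor), compound 1 `COC(=O)CC1c2ccccc2N=C(c2ccccc2)N1c1ccccc1` gives 10700 nM, compound 2 `O=C(CC1c2ccccc2N=C(N2CCCCC2)N1c1ccccc1)NCc1ccccc1` gives 900 nM, and compound 3 `Nc1ccc(CNC(=O)CC2c3ccccc3N=C(N3CCCCC3)N2c2ccccc2)cc1` gives 14400 nM. Within the data shown here, compound 3 therefore carries the highest of the three numbers; its gap to compound 1 lies within the scatter, whereas the step of a 16-fold higher number from compound 2 to compound 3 (1.20 log units; beyond the scatter) is the one large step among the measured pairs. Compound 4 `Cc1ccc(S(=O)(=O)Nc2ccc(CNC(=O)CC3c4ccccc4N=C(N4CCCCC4)N3c3ccccc3)cc2)cc1` differs from compound 3 in a single place: (4-methylphenyl)sulfonyl in place of hydrogen on a nitrogen on an aromatic ring. Among the measured compounds shown here, no measured pair shows this change directly. For the measured compounds named here, the only step that touches the same nitrogen is a 16-fold higher number from compound 2 to compound 3 (1.20 log units; beyond the scatter), which runs from a hydrogen to the free amino group and is large; compound 4 keeps that nitrogen but bears the (4-methylphenyl)sulfonyl group on it, so the free amino group of compound 3 no longer stands there, yet compound 4 is not a return to compound 2 either. A step of moderate size toward a lower number is expected for compound 4, a 4.8-fold lower number from compound 3 to compound 4 (0.68 log units; beyond the scatter), because a 16-fold higher number from compound 2 to compound 3 (1.20 log units; beyond the scatter) ties the free amino group of compound 3 to the higher numbers in the set and compound 4 no longer carries it unchanged. The estimate for compound 4 in this assay is 3000 nM, within the range 600 nM to 15000 nM.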

Compound 4, half-maximal inhibitory concentration: 250 nM
The estimate for compound 4 lay 12-fold (1.08 log units) above the measured number; the whole stated range lies above it.
By their numbers in this assay, from the lowest: compound 4; then compound 2; then compounds 1 and 3 (each within the scatter of the next).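

In this assay, the nitrogen on an aromatic ring proves to be a place where substitution changes the number sharply: a 58-fold lower number from compound 3 to compound 4 (1.76 log units; beyond the scatter) is large and runs opposite to the earlier rise on adding the amino group, a 16-fold higher number from compound 2 to compound 3 (1.20 log units; beyond the scatter). The high number of compound 3 is therefore not a penalty for any nitrogen at this place, since a 3.6-fold lower number from compound 2 to compound 4 (0.56 log units; beyond the scatter) shows that the ((4-methylphenyl)sulfonyl)amino group gives a lower number than the plain hydrogen on that aromatic carbon, a modest step but one beyond the scatter. Nothing available here accounts for either step, and the numbers show only their direction and size.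

The compounds shown leave open what a methylsulfonyl, an acetyl or a plain phenylsulfonyl group on that nitrogen would give, so the contribution of the sulfonyl link cannot be separated from that of the 4-methylphenyl ring. Also open, from the compounds shown here alone, is whether a chloro or methoxy group in place of the methyl on that ring would move the number further in either direction.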